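Predicting a Dichlorophenyl Analogue from a Bromophenyl Step

A few compounds are considered here, and "the series" means these few. Any claim that something is new, unique, unknown or untested is made for them only; others in the source may bear on it.

Compound 1 `O=C(CCCCC1CCSS1)NCc1cn(CCCOc2ccc3ccc(=O)oc3c2)nn1` was tested in a functional assay on PC-12 cells (Rattus norvegicus) for cytotoxicity, read by MTT assay, with stated times of 3 h and 2 h, tested at 10 uM (a lower number here means a weaker effect, a higher number a stronger effect of the compound at the concentration tested), and in this test compound 1 gives 40%. Among the three compounds measured, compound 1 stands second highest. Compound 2 `CCOC(=O)c1cc2ccc(OCCCn3cc(CNC(=O)CCCCC4CCSS4)nn3)cc2oc1=O` gives 36.1% in this assay; the step of a number 3.9 percentage points lower from compound 1 to compound 2 (within the scatter) lies within the scatter. Compound 3 `O=C(CCCCC1CCSS1)NCc1cn(CCCOc2ccc3cc(-c4ccc(Br)cc4)c(=O)oc3c2)nn1` gives 63.3% in this assay, and the step of a number 23.3 percentage points higher from compound 1 to compound 3 (beyond the scatter) is the one that matters here, as is the related step of a number 27.2 percentage points higher from compound 2 to compound 3 (beyond the scatter).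

Compound 4 `O=C(CCCCC1CCSS1)NCc1cn(CCCOc2ccc3cc(-c4ccc(Cl)c(Cl)c4)c(=O)oc3c2)nn1` differs from compound 1 by 3,4-dichlorophenyl in place of hydrogen on an aromatic carbon. For the measured compounds named here, this change resembles the one from compound 1 to compound 3, where an aryl group entered at the same aromatic carbon and the number rose by a modest amount beyond the scatter. Compound 4 is therefore expected to show a similar step, a number 22 percentage points higher from compound 1 to compound 4 (beyond the scatter), in this assay. For compound 4 the estimated value is 62%, with a likely range from 48% to 76%.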

Compound 4, a percentage reported as activity, at one concentration (the size of the read-out at that concentration, not a potency): 49.6%
Beside the measured number, compound 4's estimate is 12.4 percentage points above it; the measured number falls inside the stated range.
By their numbers in this assay, from the lowest: compounds 2, 1 and 4 (each within the scatter of the next, the first and the last beyond it); then compound 3.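

At this aromatic carbon, an aryl group does not by itself move the number in this assay beyond the scatter: 3,4-dichlorophenyl in place of hydrogen gives the step (a number 9.6 percentage points higher from compound 1 to compound 4 (within the scatter)). The identity of the aryl group therefore counts here, since 3,4-dichlorophenyl in place of 4-bromophenyl gives a step beyond the scatter (a number 13.7 percentage points lower from compound 3 to compound 4 (beyond the scatter)). Ethoxycarbonyl at the same carbon also separates from 3,4-dichlorophenyl (a number 13.5 percentage points higher from compound 2 to compound 4 (beyond the scatter)), so compound 4 lies within the scatter of compound 1 yet beyond that of compound 2. Nothing in the data at hand explains why the two aryl groups differ. From the compounds shown here alone, whether an unsubstituted phenyl or a 4-chlorophenyl at this carbon would fall nearer compound 3 or compound 4 remains open, as does the effect of an amine or a carboxylic acid there.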